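A few compounds are considered here, and "the series" means these few. Any claim that something is new, unique, unknown or untested is made for them only; others in the source may bear on it.

Compound 2, `Cc1oc2c([C@H]3CCN(C)C[C@H]3O)c(O)cc(O)c2c(=O)c1C(O)c1ccc([N+](=O)[O-])cc1`, gives 2% in a functional assay on MIA PaCa-2 cells (Homo sapiens) for inhibition, read by MTT assay, with a stated time of 48 h, tested at 10 uM (a lower number here means less inhibition of growth, a higher number more inhibition of growth at the concentration tested), the lowest of the two numbers shown. Compound 1, `Cc1cc(=O)c2c(O)c(CN3CCCC3)c(O)c([C@H]3CCN(C)C[C@H]3O)c2o1`, gives 28% in this assay, a gap that lies beyond the usual scatter. Compound 3, `Cc1oc2c([C@H]3CCN(C)C[C@H]3O)c(O)cc(O)c2c(=O)c1C(O)c1ccc(F)cc1`, differs from compound 2 in one place: fluoro in place of nitro on an aromatic carbon. Going by the values given here, no measured pair shows this change, so its effect is unknown from the data; compound 3 is expected to give a step of a number 6 percentage points higher from compound 2 to compound 3 (within the scatter) that does not clearly exceed the scatter. Compound 3 is therefore estimated at 8%, within a range from 0% to 25%.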

Compound 3, percent growth inhibition at one concentration: 17%
Beside the measured number, compound 3's estimate is 9 percentage points below it, within the range that was stated.
By their numbers in this assay, from the lowest: compound 2; then compound 3; then compound 1.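

In this assay, fluoro in place of nitro on this aromatic carbon gives a number 15 percentage points higher from compound 2 to compound 3 (beyond the scatter), showing that the group held at this position alters the reading. Going by these compounds alone, compound 1 differs from compound 2 in more than one place, so only this pair isolates the position. Nothing available accounts for the size or direction of this step. From the compounds shown here alone, whether an amine or a carboxylic acid at this carbon would shift the number further remains open, as does whether the same change would have a similar effect on the core of compound 1.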